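This account rests on a few compounds, and the source may have more. Where it says the series, first, only, none or still open, it means among the compounds named here.

Working notes on the series. Three compounds share one core and differ only in the aryl group on a saturated ring carbon. Compound 1 `CC(C)=CCOc1ccc2c(c1)OC(c1cccc(Cl)c1)CC2=O` gives 6300 nM in a functional assay; a lower number here means a stronger inhibitor, a higher number a weaker inhibitor. Compound 2 `CC(C)=CCOc1ccc2c(c1)OC(c1cccc(Br)c1)CC2=O` gives 5280 nM in this assay, and compound 3 `CC(C)=CCOc1ccc2c(c1)OC(c1ccc(O)cc1)CC2=O` gives 6670 nM in this assay. Going by the values given here, compound 2 holds the lowest of the three numbers, yet the step of a 1.2-fold lower number from compound 1 to compound 2 (0.08 log units; within the scatter) and the step of a 1.3-fold higher number from compound 2 to compound 3 (0.10 log units; within the scatter) both lie within the scatter, as does the step of a 1.1-fold higher number from compound 1 to compound 3 (0.02 log units; within the scatter), so no compound can be called stronger than another on these data.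

Compound 4 `CC(C)=CCOc1cc(O)c2c(c1)OC(c1cccc(Br)c1)CC2=O` is not yet measured. Against compound 2 the change is hydroxy in place of hydrogen on an aromatic carbon. Among the compounds with values here, no measured step touches the aromatic ring of the core; all three steps exchange the aryl group on the saturated ring carbon, so none bears directly on this change. What the measured steps do show is that every change tried so far left this assay unmoved beyond the scatter, and the same is expected here: the step of a 1.1-fold lower number from compound 2 to compound 4 (0.02 log units; within the scatter) is expected to stay within the scatter. Compound 4 is therefore estimated at 5000 nM in this assay, with a range from 1500 nM to 16000 nM.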

Compound 4, half-maximal inhibitory concentration: 4040 nM
For compound 4 the middle estimate is 1.2-fold (0.09 log units) above the measured one, and the stated range covers the measured number.
By their numbers in this assay, from the lowest: compounds 4, 2, 1 and 3 (each within the scatter of the next).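

Going by these compounds alone, compound 4 carries the first change on the aromatic ring of the shared core: a hydroxy group on a carbon ortho to a fused ring and meta to the (3-methylbut-2-en-1-yl)oxy group, whereas all earlier steps exchanged the aryl group on the saturated ring carbon. With a 1.3-fold lower number from compound 2 to compound 4 (0.12 log units; within the scatter) in this assay as the step, this position accepts hydroxy in place of hydrogen without a shift beyond the scatter, so the insensitivity seen among compounds 1, 2 and 3 now extends, for this one change, to a second site on the molecule. No measurement on hand bears on why this change leaves the number within the scatter.

The compounds shown leave open whether a different group on this carbon, such as methoxy, an amine or a carboxylic acid, would move the number beyond the scatter. They also leave open whether the same hydroxy group would behave alike with the 3-chlorophenyl or 4-hydroxyphenyl group of compound 1 or compound 3 on the saturated ring carbon.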